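This account rests on a few compounds, and the source may have more. Where it says the series, first, only, none or still open, it means among the compounds named here.

In a functional assay on the whole organism for antagonist activity, with Rattus norvegicus as the target, at a dose of 10 mg/kg by the oral route (a lower number here means that less compound is needed, a higher number that more compound is needed for the effect), compound 1 `CCc1c(OC)nc2nc(-c3nc(C)cs3)cn2c1C` gives 10 mg/kg. Within the data shown here, of the two compounds measured so far, compound 1 carries the lowest number; its nearest neighbour is compound 2 `CCc1c(SC)nc2nc(-c3nc(C)cs3)cn2c1C`, which in this assay gives 50 mg/kg. Among the measured compounds shown here, the single measured step, a 5.0-fold higher number from compound 1 to compound 2 (0.70 log units; beyond the scatter), alters a group on the shared core, not on the five-membered ring. Compound 3 `CCc1c(OC)nc2nc(-c3nc(C(F)(F)F)cs3)cn2c1C` differs from compound 1 in a different place: trifluoromethyl in place of methyl on an aromatic carbon. Both the group that leaves and the group that enters sit on an aromatic carbon of the five-membered aromatic ring with one nitrogen and one sulfur, next to the ring nitrogen. For the measured compounds named here, no measured step touches this ring, so the comparison of compound 1 with compound 2 says nothing direct about what this change does. The step expected in this assay is therefore no change at the digits printed from compound 1 to compound 3 (within the scatter), with no firm direction, and a wide range is the honest statement. The estimate for compound 3 in this assay is 10 mg/kg, with a range from 3 mg/kg to 50 mg/kg.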

Compound 3, minimum effective dose: > 50 mg/kg
Compound 3 gave a limit, no number; the forecaster's own chance of this, stated with the estimate: 20%; middle value at least 5.0-fold (0.69 log units) from the limit.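

Until now only a change on the shared core had been seen to matter; this result adds a second sensitive place, since trifluoromethyl in place of methyl on an aromatic carbon of the five-membered ring, next to the ring nitrogen, brings an at least 5.0-fold higher number from compound 1 to compound 3 (0.69 log units; beyond the scatter) in this assay. For compound 3, the entry > 50 mg/kg is a limit of the assay and not a number, so the step tells a minimum size and no exact one. The methyl group at this position therefore cannot be exchanged freely, at least not for trifluoromethyl, and the reading rests on a single bounded value: the limit of > 50 mg/kg in this assay, at which 1 of the 3 values shown sits.

The compounds shown do not tell which feature of the exchange matters, and this one pair cannot separate the added fluorine atoms from any other difference between the two groups. Also open, going by these compounds, is how a bare hydrogen, a chlorine atom, an ethyl chain or an amine on this same carbon would behave, and so whether methyl is a particularly good group here or merely one of several that are tolerated.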